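Replacing a diethylamino group by a primary amine

The source may report more compounds than this note shows. Statements on the series, on what has been measured and on what is new or still open speak of the compounds shown alone.

Measured so far:
Compound 1, `CCN(CC)CCNc1nnc(-c2ccccc2)cc1C`: in a functional assay on the whole organism with Mus musculus as the target (a lower number here means that less compound is needed, a higher number that more compound is needed for the effect), compound 1 gives > 10 mg/kg, which is a limit of the assay and not a number.
Compound 2, `Cc1cc(-c2ccccc2)nnc1NCCN(C)C`: in this assay compound 2 gives 10 mg/kg.

Compound 1 stands only as a limit, as the limit of > 10 mg/kg in this assay, at which 1 of the 2 values shown sits, shows. For the measured compounds named here, the single step among the measured compounds, a number no higher from compound 1 to compound 2 (the limit leaves the size open), therefore has no readable size; it shows only that the dose did not become higher.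

Compound 3, `Cc1cc(-c2ccccc2)nnc1NCCCN`, has not yet been measured. It differs from compound 1 in one place: aminomethyl in place of diethylamino on a saturated chain carbon, two bonds along the chain from a nitrogen on an aromatic ring. Going by the values given here, the only measured step that bears on this change is the one from compound 1 to compound 2, where the same diethylamino group left the same chain carbon and was replaced by a smaller amine. With that step open in size, no step beyond the scatter can be predicted for compound 3 in either direction. The estimate for compound 3 in this assay is 10 mg/kg, expected to fall between 3 mg/kg and 30 mg/kg. This estimate means an expected step of a number no higher from compound 1 to compound 3 (the limit leaves the size open), with a real chance that again only a limit is reported.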

Compound 3, minimum effective dose: 0.1 mg/kg
Beside the measured number, compound 3's estimate is 100-fold (2.00 log units) above it, outside the stated range (below it).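

At this place on the chain, two bonds along from the nitrogen on the aromatic ring, the amine group can change the dose by far more than the earlier pair could reveal, and in this assay replacing diethylamino with aminomethyl brings an at least 100-fold lower number from compound 1 to compound 3 (2.00 log units; beyond the scatter). For the compounds shown here, the only step here with a fully readable size is a 100-fold lower number from compound 2 to compound 3 (2.00 log units; beyond the scatter), for aminomethyl in place of dimethylamino, so the large change does not depend on the limit and shows that removing the smaller dimethylamino group still matters greatly. The step from the diethylamino compound gives only the smallest size it could have, and its true size stays open: the limit of > 10 mg/kg in this assay, at which 1 of the 3 values shown sits.

The compounds shown leave open whether the lower dose follows from the free primary amine, which brings a hydrogen-bond donor that diethylamino lacks, or from the longer 3-aminopropyl chain, since the two differences arrive together. A 3-(dimethylamino)propyl group, a 3-(methylamino)propyl group or a longer 4-aminobutyl chain on the same core would help to separate these possibilities, and nothing here explains why the dose falls.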